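The compounds below may be only part of what the source reports. "The series", "measured", "known", "first", "only" and "open" are said of these compounds alone.

Compound 1 `Cc1cc(C)cc(S(=O)(=O)c2cnc3cc(F)ccc3c2N2CCC(C)CC2)c1`: 80% in an assay on isolated protein for displacement of a labelled ligand from metabotropic glutamate receptor 5 (Homo sapiens), with a stated time of 60 min, tested at 1 uM; on this read-out higher numbers stand for more inhibition at the one concentration tested (going by the name of the read-out) and lower numbers for less inhibition
Compound 2 `CC1CCN(c2c(S(=O)(=O)c3ccc(Cl)cc3)cnc3cc(F)ccc23)CC1`: 90%
Compound 3 `Cc1cc(C)cc(S(=O)(=O)c2cnc3ccc(Cl)cc3c2N2CCC(C)CC2)c1`: 49%

Compound 1 and compound 2 share a core and differ in one place: 4-chlorophenyl in place of 3,5-dimethylphenyl on a sulfonyl sulfur. This change gave a number 10 percentage points higher from compound 1 to compound 2 (within the scatter), so the two numbers cannot be told apart with confidence.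

Compound 3 sits on a different core. The difference between the core of compound 1 and that of compound 3 is not broken down here. In this assay compound 3 gives 49%, which is lower than compound 1 and compound 2 by more than the usual scatter.

Compound 4 `CC1CCN(c2c(S(=O)(=O)c3ccc(Cl)cc3)cnc3ccc(Cl)cc23)CC1` has not yet been measured. It differs from compound 3 by 4-chlorophenyl in place of 3,5-dimethylphenyl on a sulfonyl sulfur, the same change, at the same place, that was made from compound 1 to compound 2. On the evidence of that pair the change is expected to make only a small step, a number 8 percentage points higher from compound 3 to compound 4 (within the scatter), and compound 4 is therefore estimated to reach about 57%, most likely between 40% and 75%. Among the compounds with values here, that rests on compound 3 giving 49% and on the one step measured with this change.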

Compound 4, a percentage reported as inhibition, at one concentration (the size of the read-out at that concentration, not a potency): 92%
Compound 4: the middle estimate sits 35 percentage points below what was measured; the measured number lies above the stated range.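

Swapping 3,5-dimethylphenyl for 4-chlorophenyl on the sulfonyl sulfur gave, in this assay, a number 43 percentage points higher from compound 3 to compound 4 (beyond the scatter), and this step does not match the one seen on the other core: the same change on two cores in this assay, a number 10 percentage points higher (within the scatter) from compound 1 to compound 2 and a number 43 percentage points higher (beyond the scatter) from compound 3 to compound 4, 33 percentage points apart, beyond the scatter of two such steps

This shows that, in this series, the size of the step measured on one core was a poor guide to its size on the other, so the change cannot be treated as adding a fixed amount wherever it is placed. It does not show why the two steps differ, and two pairs give no rule for any further core; these numbers are also percentages at a single concentration, so they do not tell how far potency moved.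

The compounds shown leave open how other groups on the sulfonyl sulfur, such as a nitrile-bearing phenyl, a methoxyphenyl or a plain alkyl chain, would behave on these two cores. They also leave open whether 4-chlorophenyl would give a small step or a large one on a third core.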